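A few compounds are considered here, and "the series" means these few. Any claim that something is new, unique, unknown or untested is made for them only; others in the source may bear on it.

Measured so far in a functional assay on HEK293 cells for antagonist activity at metabotropic glutamate receptor 5 (Homo sapiens), read by FLIPR and calcium flux; a higher number here means a weaker inhibitor, a lower number a stronger inhibitor:
compound 1 `COc1ccc(C(=O)N[C@H]2CCC[C@H](NC(=O)c3cccc(Cl)c3)C2)cc1` gives 266 nM
compound 2 `O=C(N[C@H]1CCC[C@H](NC(=O)c2cnccn2)C1)c1cccc(Cl)c1` gives 1370 nM
compound 3 `O=C(N[C@H]1CCC[C@H](NC(=O)c2cccc(Cl)c2)C1)c1cccnc1` gives 612 nM

Compound 3 stands second highest of the three numbers in this assay. Its nearest neighbour is compound 2, separated by the step of a 2.2-fold lower number from compound 2 to compound 3 (0.35 log units; beyond the scatter); its furthest is compound 1, separated by the step of a 2.3-fold higher number from compound 1 to compound 3 (0.36 log units; beyond the scatter). Both steps are beyond the scatter, so compound 3 sits between the two in a real sense.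

Compound 4 `O=C(N[C@H]1CCC[C@H](NC(=O)c2ccccc2F)C1)c1cccc(Cl)c1` differs from compound 3 in one place: 2-fluorophenyl in place of pyridin-3-yl on a carbonyl carbon. The step that bears most directly on this is a 2.3-fold higher number from compound 1 to compound 3 (0.36 log units; beyond the scatter), where the 4-methoxyphenyl ring, a six-membered aromatic ring of carbon only, gave the lower number and pyridin-3-yl the higher. The steps of a 5.2-fold higher number from compound 1 to compound 2 (0.71 log units; beyond the scatter) and a 2.2-fold lower number from compound 2 to compound 3 (0.35 log units; beyond the scatter) show the same direction for the two rings with a hetero atom, both above compound 1. Going by the values given here, no measured compound carries 2-fluorophenyl on this carbonyl carbon, so the size for that ring is not known from the series. On this basis a modest lowering of the number is expected for compound 4, of about a 1.7-fold lower number from compound 3 to compound 4 (0.24 log units; within the scatter). The estimate for compound 4 in this assay is 350 nM, with a range from 150 nM to 900 nM.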

Compound 4, half-maximal inhibitory concentration: 175 nM
Compound 4: middle estimate off by 2.0-fold (0.30 log units), on the high side; low and high end bracket the measured number.
By their numbers in this assay, from the lowest: compounds 4 and 1 (each within the scatter of the next); then compound 3; then compound 2.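

In this assay, the 2-fluorophenyl ring on this carbonyl carbon, a six-membered aromatic ring of carbon only, gives a clear gain over both rings with a hetero atom (a 3.5-fold lower number from compound 3 to compound 4 (0.54 log units; beyond the scatter); a 7.8-fold lower number from compound 2 to compound 4 (0.89 log units; beyond the scatter)), and the larger of these steps is the one against pyrazin-2-yl. Until now 4-methoxyphenyl was the only carbon-only ring at this place, and the step to 2-fluorophenyl (a 1.5-fold lower number from compound 1 to compound 4 (0.18 log units; within the scatter)) does not separate the two, so across these four compounds both carbon-only rings stand apart from pyridin-3-yl and pyrazin-2-yl, and the low end of the series is not tied to the 4-methoxyphenyl group alone. Nothing at hand gives a reason for this gap between the carbon-only rings and the rings with a hetero atom.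

On these data alone, whether the carbon-only ring needs any substituent at all remains open, as does the outcome with plain phenyl, 2-chlorophenyl or a ring carrying an aminomethyl group at this carbonyl carbon. As far as these compounds go, the other amide ring is the same in all four compounds, so how far these steps hold with a different ring there also remains open.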